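The source may hold more compounds than are shown below. What is called first, only, known or untested is meant among the compounds shown, and "the series" means these compounds.

In a functional assay on PC-3 cells (Homo sapiens) for inhibition, read by MTT assay, with a stated time of 48 h (a lower number here means a stronger inhibitor, a higher number a weaker inhibitor), compound 1 `COc1ccc(-n2c(S)nnc2-c2cc(OC)c(OC)c(OC)c2)cc1`, which has hydrogen on its sulfur, gives > 60000 nM, and this is a limit of the assay, not a number. Compound 2 `COc1ccc(CSc2nnc(-c3cc(OC)c(OC)c(OC)c3)n2-c2ccc(OC)cc2)cc1` gives 40300 nM, and compound 3 `COc1ccc(-n2c(SCc3ccc(F)cc3)nnc2-c2cc(OC)c(OC)c(OC)c2)cc1` gives 35000 nM. These two values cannot be told apart, as the swap of methoxy for fluoro shows a 1.2-fold lower number from compound 2 to compound 3 (0.06 log units; within the scatter). Compound 3 therefore stands with compound 2 on these numbers.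

Compound 4 `COc1ccc(-n2c(SCC(=O)C3CC3)nnc2-c2cc(OC)c(OC)c(OC)c2)cc1` has cyclopropylcarbonyl in place of 4-fluorophenyl on a saturated chain carbon bound to a sulfur. Within the data shown here, this is a larger change than the one between the two benzyl compounds, and no measured step replaces the aromatic ring in this way.

The nearest guides are modest. Adding a benzyl group to the sulfur gave an at least 1.4-fold lower number from compound 1 to compound 2 (0.17 log units; that floor lies within the scatter) and an at least 1.7-fold lower number from compound 1 to compound 3 (0.23 log units; that floor lies within the scatter), and neither floor clears the scatter. With that evidence, no step beyond the scatter is expected in this assay, in either direction, although compound 4 could also reach only the limit of the assay. The expected change is a 1.1-fold higher number from compound 3 to compound 4 (0.06 log units; within the scatter). For compound 4, the estimated value is 40000 nM, with an expected range from 15000 nM to 80000 nM.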

Compound 4, half-maximal inhibitory concentration: 37200 nM
Beside the measured number, compound 4's estimate is 1.1-fold (0.03 log units) above it; measured number inside the range.
By their numbers in this assay, from the lowest: compounds 3, 4 and 2 (each within the scatter of the next). At a limit, above all of these: compound 1.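

In this assay, the aromatic ring on the saturated chain carbon bound to a sulfur can give way to cyclopropylcarbonyl, with its three-membered non-aromatic ring and one hydrogen-bond acceptor, without a step that clears the scatter: the printed steps are a 1.1-fold higher number from compound 3 to compound 4 (0.03 log units; within the scatter) and a 1.1-fold lower number from compound 2 to compound 4 (0.03 log units; within the scatter). The two benzyl compounds could show only a swap on an aromatic ring, whereas this change replaces the ring itself, and the three compounds substituted on sulfur still cannot be told apart. The step from hydrogen on sulfur, an at least 1.6-fold lower number from compound 1 to compound 4 (0.20 log units; that floor lies within the scatter), again gives only a floor, and compound 1 carries a limit of the assay rather than a number: the limit of > 60000 nM in this assay, at which 1 of the 4 values shown sits.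

Going by these compounds, it remains open whether any group at this position can move the number beyond the scatter, since these three groups give values that cannot be separated. An amine or a carboxylic acid on the chain bound to the sulfur, or a longer chain, would test this position with groups unlike those shown here.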